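Methoxy Added to the Naphthoyl Amide of Compound 2

The source may report more compounds than this note shows. Statements on the series, on what has been measured and on what is new or still open speak of the compounds shown alone.

Among the compounds with values here, compound 2 `COC1=C(CC(C)(C)CNC(=O)c2ccc3ccccc3c2)C(=O)c2ccccc2C1=O` is one of only two compounds so far tested in a functional assay on MCF7 cells (Homo sapiens) for cytotoxicity, read by resazurin assay, with a stated time of 3 days; a lower number here means a stronger inhibitor, a higher number a weaker inhibitor. In this assay compound 2 gives 52500 nM, the lowest of the two numbers; its nearest neighbour is compound 1 `COC1=C(CC(C)(C)CNC(=O)c2ccccc2OC)C(=O)c2ccccc2C1=O`, which in this assay gives 70700 nM, and the two lie within the scatter of each other. Within the data shown here, the single step between the measured pair, a 1.3-fold lower number from compound 1 to compound 2 (0.13 log units; within the scatter), shows that exchanging the aryl group on the carbonyl carbon barely moved the read-out. Compound 3 `COC1=C(CC(C)(C)CNC(=O)c2ccc3ccccc3c2OC)C(=O)c2ccccc2C1=O` has not yet been measured; it differs from compound 2 by methoxy in place of hydrogen on an aromatic carbon, the methoxy sitting ortho to a fused ring and ortho to a large group. Among the measured compounds shown here, the only measured step that bears on this change, a 1.3-fold lower number from compound 1 to compound 2 (0.13 log units; within the scatter), already involved a methoxy-bearing aryl on one side and a naphthalenyl on the other and stayed within scatter, so no step beyond the scatter is expected in this assay in either direction. Compound 3 is therefore expected to give about 50000 nM, with a range from 20000 nM to 125000 nM. The estimated step of a 1.1-fold lower number from compound 2 to compound 3 (0.02 log units; within the scatter) is expected to be small.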

Compound 3, half-maximal inhibitory concentration: 95700 nM
Beside the measured number, compound 3's estimate is 1.9-fold (0.28 log units) below it, within the range that was stated.
By their numbers in this assay, from the lowest: compounds 2, 1 and 3 (each within the scatter of the next).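

Within the data shown here, the step of a 1.8-fold higher number from compound 2 to compound 3 (0.26 log units; within the scatter) in this assay is the first reading of methoxy alone. The earlier step from compound 1 to compound 2 exchanged a whole aryl group on the carbonyl carbon and could not separate the methoxy from the rest of that exchange. Here only methoxy in place of hydrogen differs, on an aromatic carbon of a ring that is part of a fused or bridged system of two rings, ortho to a fused ring and ortho to a large group. The step stays within the scatter, so this one change, with its 2 heavy atoms and 1 hydrogen-bond acceptor, gives no readable shift at this position in this assay.

The compounds shown leave open whether a different group at the same aromatic carbon, such as an amine, a carboxylic acid or a longer chain like butoxy, would produce a step beyond the scatter, and whether methoxy would read the same on another carbon of this ring. No measurement shown here offers any explanation for the size of this step.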